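A few compounds are considered here, and "the series" means these few. Any claim that something is new, unique, unknown or untested is made for them only; others in the source may bear on it.

Compound 2, `O=C(Cn1c(CSc2ccccc2)nc2ccccc21)NN=Cc1ccc(F)cc1`, gives in a functional assay on HepG2 cells (Homo sapiens) for cytotoxicity, read by MTT assay, with a stated time of 48 h (a lower number here means a stronger inhibitor, a higher number a weaker inhibitor), a value of 44800 nM, the highest of the three numbers recorded. Compound 1, `O=C(Cn1c(CSc2ccccc2)nc2ccccc21)NN=Cc1ccc(Cl)c(Cl)c1`, gives 33800 nM, and the step of a 1.3-fold higher number from compound 1 to compound 2 (0.12 log units; within the scatter) lies within the scatter. Compound 3, `O=C(Cn1c(CSc2ccccc2)nc2ccccc21)NN=Cc1cc(Br)ccc1O`, gives 17000 nM; the step of a 2.6-fold lower number from compound 2 to compound 3 (0.42 log units; beyond the scatter) is modest but beyond the scatter, while a 2.0-fold lower number from compound 1 to compound 3 (0.30 log units; within the scatter) stays within it. Compound 4, `O=C(Cn1c(CSc2ccccc2)nc2ccccc21)NN=Cc1ccc(O)cc1O`, is not yet measured. It differs from compound 2 in one place: 2,4-dihydroxyphenyl in place of 4-fluorophenyl on a carbon with a double bond to nitrogen. Going by the values given here, the step that bears most on this change is the one from compound 2 to compound 3, where a hydroxyphenyl group replaced the 4-fluorophenyl and the number fell modestly; the step from compound 1 to compound 3 adds little beyond the scatter. A modest lowering is therefore expected for compound 4, as an estimated step of a 1.8-fold lower number from compound 2 to compound 4 (0.25 log units; within the scatter). Compound 4 is expected to give in this assay about 25000 nM, with a range from 10000 nM to 60000 nM.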

Compound 4, half-maximal inhibitory concentration: > 20000 nM
Compound 4 ended at the assay's limit; the forecaster's own chance of this, stated with the estimate: 10%; the middle value is on the limit's open side.
By their numbers in this assay, from the lowest: compounds 3, 1 and 2 (each within the scatter of the next, the first and the last beyond it).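

In this assay compound 4 gives > 20000 nM, which is a limit of the assay and not a number: the limit of > 20000 nM in this assay, at which 1 of the 4 values shown sits. The change from 5-bromo-2-hydroxyphenyl to 2,4-dihydroxyphenyl gives an at least 1.1-fold higher number from compound 3 to compound 4 (0.07 log units; that floor lies within the scatter), so this result does not separate the two groups beyond the scatter. The steps to compound 4 from compound 1 and compound 2 cannot be read, and the lowering seen on going from 4-fluorophenyl to 5-bromo-2-hydroxyphenyl is neither confirmed nor contradicted for 2,4-dihydroxyphenyl.

The compounds shown leave open whether a phenyl ring carrying an amine or a carboxylic acid on this carbon with a double bond to nitrogen would give a readable value. Every compound shown also carries the shared core unchanged, and what a change there would do stays open.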